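A few compounds are considered here, and "the series" means these few. Any claim that something is new, unique, unknown or untested is made for them only; others in the source may bear on it.

Working notes on a short series in a functional assay for inhibition, with Oryctolagus cuniculus as the target (on this read-out lower numbers stand for stronger inhibition and higher numbers for weaker inhibition), three members measured so far on a shared core. Compound 1 `CC(=O)/C=C/c1cccc(C)c1O` gives 3630 nM. Compound 2 `CC(=O)/C=C/c1cccc(F)c1O` gives 51200 nM. Compound 3 `COc1cccc(/C=C/C(C)=O)c1O` gives 3250 nM, the lowest number of the three, though its gap to compound 1 is within the scatter; only compound 2 stands apart, by a 16-fold lower number from compound 2 to compound 3 (1.20 log units; beyond the scatter). Of the two steps out of compound 1, a 14-fold higher number from compound 1 to compound 2 (1.15 log units; beyond the scatter) is large, whereas a 1.1-fold lower number from compound 1 to compound 3 (0.05 log units; within the scatter) is within the scatter.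

Compound 4 `CC(=O)/C=C/c1cccc(O)c1O` is the next step from compound 3: hydrogen in place of methyl on an oxygen on an aromatic ring. For the measured compounds named here, none of the measured steps touches the oxygen; all three exchange groups on an aromatic carbon, so none bears directly on this change. Going by the values given here, the only indirect guidance is that compound 1 and compound 3 give close values, while compound 2 with fluoro falls far behind, so the series is sensitive to what sits at that aromatic carbon but gives no precedent for methoxy against hydroxy. Among the compounds with values here, with no direct precedent, the step from compound 3 is expected to stay small, as a 1.1-fold lower number from compound 3 to compound 4 (0.03 log units; within the scatter), with wide uncertainty in either direction. Compound 4 is therefore estimated at 3000 nM, in a range from 800 nM to 12000 nM.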

Compound 4, half-maximal inhibitory concentration: 1960 nM
Compound 4: the middle estimate sits 1.5-fold (0.18 log units) above what was measured, within the range that was stated.
By their numbers in this assay, from the lowest: compounds 4, 3 and 1 (each within the scatter of the next); then compound 2.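

In this assay, the first comparison made on the oxygen on an aromatic ring shows that the methyl there can give way to hydrogen without a reading beyond the scatter (a 1.7-fold lower number from compound 3 to compound 4 (0.22 log units; within the scatter)), so methoxy and hydroxy cannot be told apart on this read-out. Hydroxy also cannot be separated from methyl on the aromatic carbon (a 1.9-fold lower number from compound 1 to compound 4 (0.27 log units; within the scatter)), which makes compounds 1, 3 and 4 a group of three whose values stay within the scatter of one another, even though the groups at this place differ in whether the oxygen is present and whether it carries a methyl. Fluoro alone stands apart, and the step to hydroxy (a 26-fold lower number from compound 2 to compound 4 (1.42 log units; beyond the scatter)) is the largest in the series so far, but no supporting data accompany these values to account for this separation.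

The compounds shown leave open whether the weak value is peculiar to fluoro or would also appear with chloro or trifluoromethyl on the same aromatic carbon. They also leave open whether the tolerance on the oxygen extends beyond methyl to a longer chain such as ethyl, or to a group carrying an amine or a carboxylic acid.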